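Swapping Fluoro for Methoxy on the Pendant Phenyl Ring

The compounds below may be only part of what the source reports. "The series", "measured", "known", "first", "only" and "open" are said of these compounds alone.

Of the compounds shown here, three sharing one core have been measured in an ADME assay for permeability, using PAMPA, with a stated time of 30 min, at pH 7.4; on this read-out higher numbers stand for higher permeability and lower numbers for lower permeability. Compound 1 `COc1cccc(Oc2ccc3c(NCCCNCc4cc(F)ccc4OC)ccnc3c2)c1` gives 317 10^-6 cm/s. Compound 2 `COc1ccc(F)cc1CNCCCNc1ccnc2cc(Cc3ccc(F)cc3Cl)ccc12` gives 23 10^-6 cm/s. Compound 3 `COc1ccc(F)cc1CNCCCNc1ccnc2cc(-c3ccc(F)cc3)ccc12` gives 237 10^-6 cm/s, which places it second of the three: it sits close to compound 1, since the step of a 1.3-fold lower number from compound 1 to compound 3 (0.13 log units; within the scatter) lies within the scatter, and far from compound 2, as the step of a 10-fold higher number from compound 2 to compound 3 (1.01 log units; beyond the scatter) shows.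

Compound 4 `COc1ccc(-c2ccc3c(NCCCNCc4cc(F)ccc4OC)ccnc3c2)cc1` differs from compound 3 in one place: methoxy in place of fluoro on an aromatic carbon. Within the data shown here, none of the measured steps exchanges a fluoro for a methoxy. The two large steps, a 14-fold lower number from compound 1 to compound 2 (1.14 log units; beyond the scatter) and a 10-fold higher number from compound 2 to compound 3 (1.01 log units; beyond the scatter), both involve the 2-chloro-4-fluorobenzyl group, which compound 4 does not carry. The closest comparison is the step of a 1.3-fold lower number from compound 1 to compound 3 (0.13 log units; within the scatter), in which replacing 3-methoxyphenoxy by 4-fluorophenyl left this assay essentially unchanged. Because the step of a 1.3-fold lower number from compound 1 to compound 3 (0.13 log units; within the scatter) stayed within the scatter for a larger swap, the smaller exchange of fluoro for methoxy is expected to leave compound 4 within the scatter as well, with no clear direction, as a 1.1-fold lower number from compound 3 to compound 4 (0.03 log units; within the scatter) expresses. Compound 4 is therefore estimated at 220 10^-6 cm/s, with a range from 110 10^-6 cm/s to 400 10^-6 cm/s.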

Compound 4, apparent permeability: 237 10^-6 cm/s
For compound 4 the middle estimate is 1.1-fold (0.03 log units) below the measured one; the range from low to high includes it.
By their numbers in this assay, from the lowest: compound 2; then compounds 3, 4 and 1 (each within the scatter of the next).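

In this assay, the exchange of fluoro for methoxy on this aromatic carbon, para to a large group, gives no change at the digits printed from compound 3 to compound 4 (within the scatter), so at this position a methoxy of 2 heavy atoms, carrying 1 hydrogen-bond acceptor, takes the place of a single fluorine with no change beyond the scatter. Against the other two compounds, 4-methoxyphenyl reads just as 4-fluorophenyl did: the comparison with the 3-methoxyphenoxy compound gives a 1.3-fold lower number from compound 1 to compound 4 (0.13 log units; within the scatter), while the comparison with the 2-chloro-4-fluorobenzyl compound gives a 10-fold higher number from compound 2 to compound 4 (1.01 log units; beyond the scatter), which leaves that benzyl compound alone, well apart from the other three. Nothing measured here offers an explanation for why the fluoro and methoxy compounds read alike.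

Fluoro and methoxy are the only two groups shown on this carbon, so it remains open whether an amine or a carboxylic acid there would also stay within the scatter. Also open, going by these compounds, is whether the same exchange of fluoro for methoxy would read alike on the 2-chloro-4-fluorobenzyl group of compound 2.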